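The compounds below may be only part of what the source reports. "The series", "measured", "known", "first", "only" and "open" are said of these compounds alone.

Series notes. Within the data shown here, compound 1 `Nn1c(SCc2ccccc2)nnc1-c1c[nH]c2ccccc12` carries the unsubstituted benzyl thioether on the shared core; in a functional assay on MDA-MB-231 cells (Homo sapiens) for cytotoxicity, read by MTT assay, with a stated time of 72 h (on this read-out higher numbers stand for weaker inhibition and lower numbers for stronger inhibition), compound 1 gives 26500 nM, the highest of the two numbers so far. Compound 2 `Nn1c(SCc2ccccc2[N+](=O)[O-])nnc1-c1c[nH]c2ccccc12` differs by a nitro group on the benzyl ring, and in this assay compound 2 gives 9520 nM. Among the measured compounds shown here, the only step that bears on the next change is a 2.8-fold lower number from compound 1 to compound 2 (0.44 log units; beyond the scatter), a nitro in place of hydrogen on an aromatic carbon. Compound 3 `Nn1c(SCc2ccc([N+](=O)[O-])cc2)nnc1-c1c[nH]c2ccccc12` is obtained from compound 1 by nitro in place of hydrogen on an aromatic carbon: the same group, at a different position on the same ring. With a single precedent, a step of the same kind is expected for compound 3, toward a lower number, of roughly the size seen for compound 2 but without confidence in its exact extent, so that the expected step is a 2.4-fold lower number from compound 1 to compound 3 (0.38 log units; beyond the scatter). The estimate for compound 3 in this assay is 11000 nM, with a range from 4000 nM to 30000 nM.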

Compound 3, half-maximal inhibitory concentration: 740 nM
Compound 3: the middle estimate sits 15-fold (1.17 log units) above what was measured; measured number below the stated range.
By their numbers in this assay, from the lowest: compound 3; then compound 2; then compound 1.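

Placed para to a large group, the nitro gives a 36-fold lower number from compound 1 to compound 3 (1.55 log units; beyond the scatter) in this assay and that step is large, while the same group elsewhere on the ring gives only a 2.8-fold lower number from compound 1 to compound 2 (0.44 log units; beyond the scatter) and that step is modest. The exchange of hydrogen for nitro therefore has no single size on this ring: the size depends on where the group sits, with compound 3 at 740 nM against compound 2 at 9520 nM on the printed values. Nothing measured here accounts for the difference between the two positions.

On these data alone, whether the large step belongs to nitro itself or would also follow other groups at this place remains open. An amine or a carboxylic acid on the same ring carbon would address this, and a longer chain in place of the benzyl link would show how far the step depends on that link.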